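This account rests on a few compounds, and the source may have more. Where it says the series, first, only, none or still open, it means among the compounds named here.

Of the compounds shown here, two have been measured so far. Compound 1 `COc1cc2nc(/C=C\c3ccncc3)c(=O)n(CC(=O)Nc3ccccc3)c2cc1OC` gives a limit rather than a number: in an ADME assay on BEAS-2B cells (Homo sapiens) for inhibition, read by MTT assay, with a stated time of 24 h (a higher number here means a weaker inhibitor, a lower number a stronger inhibitor), compound 1 reads > 100000 nM. Compound 2 `Cc1ccc(NC(=O)COc2nc3ccccc3nc2C)cc1` likewise gives only a limit: in this assay compound 2 reads > 100000 nM. Both known values thus sit at the limit of > 100000 nM in this assay, at which 2 of the 2 values shown sit, so compound 2 stands level with compound 1 on the numbers shown, and no step between measured compounds is available. Compound 3 `Cc1nc2ccccc2nc1OCC(=O)Nc1ccc(Cl)cc1` is next to be measured in this assay. Its change from compound 2 is chloro in place of methyl on an aromatic carbon. With both known values at the same limit, no step beyond the scatter is expected in this assay in either direction, and a limit again seems the likeliest outcome. The step expected is a step that the limit leaves unreadable from compound 2 to compound 3. For compound 3 the estimate in this assay is 120000 nM, within a range from 50000 nM to 300000 nM, most probably again reported only as a limit.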

Compound 3, half-maximal inhibitory concentration: > 100000 nM
Compound 3 gave a limit, no number; the forecaster's own chance of this, stated with the estimate: 85%; the middle value is on the limit's open side.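

In this assay compound 3 gives > 100000 nM, which is a limit and not a number. Compound 2 also gives only a limit, so no step can be read between compound 2 and compound 3. The compounds shown leave open whether any member of the series gives a measurable half-maximal inhibitory concentration in this assay.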